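Working notes: heteroaryl swap from compound 2 to compound 3

The compounds below may be only part of what the source reports. "The series", "measured", "known", "first", "only" and "open" are said of these compounds alone.

Of the compounds shown here, two carry numbers so far. In an assay on isolated protein for inhibition of Rho-associated protein kinase 2 (Homo sapiens) (a lower number here means a stronger inhibitor, a higher number a weaker inhibitor), compound 1 `CC(C)Oc1ccc2c(c1)CC(c1nc3ccc(-c4ccnc(N)n4)cc3[nH]1)CO2` gives 296 nM and compound 2 `Nc1nccc(-c2ccc3nc(C4COc5ccccc5C4)oc3c2)n1` gives 27 nM. Compound 2 holds the lower of the two numbers, and compound 1 sits above it by a gap that is beyond the scatter; the two differ in more than one place, so no single change is tied to that gap.

Compound 3 `Cc1[nH]ncc1-c1ccc2nc(C3COc4ccccc4C3)oc2c1` is the next point. Its change from compound 2 is 5-methyl-1H-pyrazol-4-yl in place of 2-aminopyrimidin-4-yl on an aromatic carbon. For the measured compounds named here, no pair of measured compounds differs in this single place, so the step is unanchored. A modest rise in this assay is expected from compound 2 to compound 3, of a size that may sit beyond the scatter, though a flat outcome cannot be excluded; the expected step is a 3.0-fold higher number from compound 2 to compound 3 (0.47 log units; beyond the scatter). For compound 3 the estimated value in this assay is 80 nM, with a range from 20 nM to 400 nM.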

Compound 3, half-maximal inhibitory concentration: 9 nM
Compound 3: middle estimate off by 8.9-fold (0.95 log units), on the high side; the measured number lies below the stated range.
By their numbers in this assay, from the lowest: compound 3; then compound 2; then compound 1.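

Working notes, continued. For the compounds shown here, this is the first step that can be read at a single place: on this aromatic carbon, 5-methyl-1H-pyrazol-4-yl in place of 2-aminopyrimidin-4-yl gives a 3.0-fold lower number from compound 2 to compound 3 (0.48 log units; beyond the scatter) in this assay, so a low number here does not depend on 2-aminopyrimidin-4-yl. The entering five-membered aromatic ring has fewer heavy atoms and hydrogen-bond acceptors than the six-membered ring it replaces, with the same count of hydrogen-bond donors, and the number still falls. Nothing available explains this step.

Going by these compounds, the ring and its methyl arrive together, so the shares of the two in this step remain open; an unsubstituted 1H-pyrazol-4-yl or an ethyl in place of the methyl would separate them. On these data alone, it also remains open whether the same swap carries over to the core of compound 1.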